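Replacing the 3-Hydroxyphenyl Group in Compound 3

The source may report more compounds than this note shows. Statements on the series, on what has been measured and on what is new or still open speak of the compounds shown alone.

Measured compounds:
Compound 1 `CC(C)=CCC/C(C)=C/CC/C(C)=C/CC[C@@H]1[C@@]2(C)C/C(=C\c3ccc(OCc4cn(-c5cccc(Br)c5)nn4)cc3)C(=O)C(C)(C)[C@@H]2CC[C@@]1(C)O`: in a functional assay on HepG2 cells (Homo sapiens) for cytotoxicity, read by MTT assay, with a stated time of 48 h (a lower number here means a stronger inhibitor, a higher number a weaker inhibitor), compound 1 gives 23700 nM.
Compound 2 `CC(C)=CCC/C(C)=C/CC/C(C)=C/CC[C@@H]1[C@@]2(C)C/C(=C\c3ccc(OCc4cn(-c5cccc([N+](=O)[O-])c5)nn4)cc3)C(=O)C(C)(C)[C@@H]2CC[C@@]1(C)O`: compound 2 gives 117000 nM.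
Compound 3 `CC(C)=CCC/C(C)=C/CC/C(C)=C/CC[C@@H]1[C@@]2(C)C/C(=C\c3ccc(OCc4cn(-c5cccc(O)c5)nn4)cc3)C(=O)C(C)(C)[C@@H]2CC[C@@]1(C)O`: compound 3 gives 26900 nM.

Compound 3 stands second highest of the three numbers, close to compound 1 and well apart from compound 2. Compound 4 `COc1cc(OC)c(-n2cc(COc3ccc(/C=C4\C[C@]5(C)[C@@H](CC/C=C(\C)CC/C=C(\C)CCC=C(C)C)[C@](C)(O)CC[C@H]5C(C)(C)C4=O)cc3)nn2)c(OC)c1` differs from compound 3 in one place: 2,4,6-trimethoxyphenyl in place of 3-hydroxyphenyl on an aromatic nitrogen. The steps touching compound 3 are a 1.1-fold higher number from compound 1 to compound 3 (0.06 log units; within the scatter) and a 4.3-fold lower number from compound 2 to compound 3 (0.64 log units; beyond the scatter), so the hydroxy and bromo compounds lie together while the nitro compound lies well apart. Among the compounds with values here, no measured step introduces a 2,4,6-trimethoxyphenyl group, so the direction is uncertain. For compound 4 the expected step is a 1.2-fold higher number from compound 3 to compound 4 (0.08 log units; within the scatter), within the scatter. Compound 4 is therefore estimated at 32000 nM, with a range from 10000 nM to 100000 nM.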

Compound 4, half-maximal inhibitory concentration: 57500 nM
Estimate against measurement, compound 4: 1.8-fold (0.25 log units) below; low and high end bracket the measured number.
By their numbers in this assay, from the lowest: compounds 1 and 3 (each within the scatter of the next); then compound 4; then compound 2.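

The 2,4,6-trimethoxyphenyl group gives a level of its own at this position in this assay, with a 2.1-fold higher number from compound 3 to compound 4 (0.33 log units; beyond the scatter) and a 2.4-fold higher number from compound 1 to compound 4 (0.38 log units; beyond the scatter) on one side and a 2.0-fold lower number from compound 2 to compound 4 (0.31 log units; beyond the scatter) on the other. Within the data shown here, a larger group on this aromatic nitrogen therefore leaves the number between those of the bromo and hydroxy pair and the nitro compound, and brings no gain over that pair. Nothing shown accounts for this order.

The compounds shown leave open what a single methoxy group, an amine or a carboxylic acid on this phenyl ring would do. They also leave open whether any group here can bring the number clearly below that of compound 3.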